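The source may report more compounds than this note shows. Statements on the series, on what has been measured and on what is new or still open speak of the compounds shown alone.

Measured compounds:
compound 1, `O=C(CCCCCCc1cccc(Cl)c1)N1CCCC1`: 3700 nM
compound 2, `O=C(CCc1ccc(-c2cccc(F)c2)cc1)N1CCCC1`: 1800 nM

Both numbers come from an assay on HEK293 cells for inhibition of N-acylethanolamine-hydrolyzing acid amidase (Rattus norvegicus), read by LC-MS, with a stated time of 30 min; a lower number here means a stronger inhibitor, a higher number a weaker inhibitor. Of the two, compound 1 stands at the higher end: compound 2 sits at a lower number in this assay, and the gap between them is beyond the usual scatter. Going by the values given here, no step between two measured compounds that differ in one place is available, so the change considered below has no measured precedent within this set.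

Compound 3, `COC(=O)c1cccc(CCCCCCC(=O)N2CCCC2)c1`, is yet to be measured in this assay. It differs from compound 1 in one place: methoxycarbonyl in place of chloro on an aromatic carbon. Among the compounds with values here, with no matched step to lean on, the expected step is a 1.2-fold lower number from compound 1 to compound 3 (0.09 log units; within the scatter) in this assay, a change not expected to exceed the scatter in either direction. Compound 3 is accordingly estimated at 3000 nM in this assay, with a range from 800 nM to 12000 nM.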

Compound 3, half-maximal inhibitory concentration: > 100000 nM
Compound 3: a limit, no number (the forecaster's own chance of this, stated with the estimate: 10%); at least 33-fold (1.52 log units) between middle value and limit.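

In this assay the replacement of chloro by methoxycarbonyl on an aromatic carbon, meta to a large group, gives an at least 27-fold higher number from compound 1 to compound 3 (1.43 log units; beyond the scatter) and shows that activity in this series is sensitive to the group at this position. As far as these compounds go, the value for compound 3 is a limit of the assay and not a number, so the full size of this step stays unknown: the limit of > 100000 nM in this assay, at which 1 of the 3 values shown sits. The change brings 4 heavy atoms and 2 hydrogen-bond acceptors where chloro had 1 heavy atom and 0 hydrogen-bond acceptors, but this single step cannot separate those differences or assign a cause.

From the compounds shown here alone, it remains open whether the loss extends to smaller groups at this position, such as methyl or nitrile. A carboxylic acid or a primary amide there would show whether it extends to other carbonyl groups.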